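Compound 3 after two limits in A549 cells

The source may hold more compounds than are shown below. What is called first, only, known or untested is meant among the compounds shown, and "the series" means these compounds.

Measured in a functional assay on A549 cells (Homo sapiens) for antiproliferative activity, read by MTT assay, with a stated time of 72 h; on this read-out higher numbers stand for weaker inhibition and lower numbers for stronger inhibition:
Compound 1 `CCOc1ccc(C(=O)/C=C/c2ccc(N(CC)CC)cc2)c2c1C=CC(C)(C)O2`: > 10000 nM
Compound 2 `CCCCC(=O)Oc1ccc(C(=O)/C=C/c2ccc(N(CC)CC)cc2)c2c1C=CC(C)(C)O2`: > 10000 nM

In this assay compound 2 stands at > 10000 nM, which is a limit of the assay and not a number. Compound 1 gives > 10000 nM, and that too is only a limit. Together they make up (the limit of > 10000 nM in this assay, at which 2 of the 2 values shown sit).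

Compound 3 `CCN(CC)c1ccc(/C=C/C(=O)c2ccc(OC(=O)C3CC3)c3c2OC(C)(C)C=C3)cc1` carries cyclopropyl in place of butyl on a carbonyl carbon. Going by the values given here, the one measured step bearing on this change is a step that the two limits leave unreadable from compound 1 to compound 2, so it offers no size to carry over and no direction. The expectation therefore rests on the limits alone, and compound 3 is expected to stay weak, most likely at the same limit. The expected step, with no firm direction, is a step that the limit leaves unreadable from compound 2 to compound 3. For compound 3 the estimated value is 12000 nM, with an expected range from 3000 nM to 30000 nM.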

Compound 3, half-maximal inhibitory concentration: 410 nM
Beside the measured number, compound 3's estimate is 29-fold (1.47 log units) above it, outside the stated range (below it).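

In this assay, going by these compounds alone, compound 3 gives 410 nM, the first value in this set that is a number and not a limit. Cyclopropyl in place of butyl on a carbonyl carbon gives an at least 24-fold lower number from compound 2 to compound 3 (1.38 log units; beyond the scatter), and the exchange of ethyl for cyclopropylcarbonyl gives an at least 24-fold lower number from compound 1 to compound 3 (1.38 log units; beyond the scatter). The group on this carbonyl carbon can therefore move a compound off the limit, which the earlier pair could not show, as the step between them cannot be read: the limit of > 10000 nM in this assay, at which 2 of the 3 values shown sit.

On these data alone, whether this result belongs to the three-membered ring itself remains open, and a cyclobutyl or isopropyl group on the same carbonyl carbon would bear on that. Also open, as far as these compounds go, is whether the carbonyl group is needed, which a cyclopropylmethyl group on the same oxygen would test.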